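Cyclopropyl in place of methoxy on compound 3

The source may hold more compounds than are shown below. What is called first, only, known or untested is meant among the compounds shown, and "the series" means these compounds.

In a physicochemical assay for lipophilicity, using the shake flask method, measured as octanol-water partition, at pH 7.4 (a higher number here means a more lipophilic compound, a lower number a more polar compound), compound 3 (`COCC(=O)N[C@H]1[C@H]([C@@H](O)[C@H](O)CNC(=O)c2ccc(Cl)cc2)O[C@@](OCc2cccc(F)c2F)(C(=O)O)C[C@@H]1O`) gives 0.06 as its reading, within the scatter of compound 2 (`CS(=O)(=O)N[C@H]1[C@H]([C@@H](O)[C@H](O)CNC(=O)c2ccc(Cl)cc2)O[C@@](OCc2cccc(F)c2F)(C(=O)O)C[C@@H]1O`) at -0.17 on this scale, and clearly under compound 1 (`O=C(NC[C@@H](O)[C@H](O)[C@@H]1O[C@@](OCc2cccc(F)c2F)(C(=O)O)C[C@H](O)[C@H]1NS(=O)(=O)c1ccccc1[N+](=O)[O-])c1ccc(Cl)cc1`) at 0.87 in the same assay. Compound 4 (`O=C(CC1CC1)N[C@H]1[C@H]([C@@H](O)[C@H](O)CNC(=O)c2ccc(Cl)cc2)O[C@@](OCc2cccc(F)c2F)(C(=O)O)C[C@@H]1O`) differs from compound 3 by cyclopropyl in place of methoxy on a saturated chain carbon bound to a carbonyl carbon and so gains a carbon-only group. Going by the values given here, no measured step makes this exact change. Changes on the same amine nitrogen bear on it only indirectly: a number 1.04 log units lower from compound 1 to compound 2 (beyond the scatter) and a number 0.81 log units lower from compound 1 to compound 3 (beyond the scatter) show that this part can move the number, whereas a number 0.23 log units higher from compound 2 to compound 3 (within the scatter) shows a swap that does not. An upward move of similar size to the modest step to compound 3 is therefore expected, namely a number 0.74 log units higher from compound 3 to compound 4 (beyond the scatter) as estimated here. Compound 4 is estimated at 0.8 with an expected range of 0.4 to 1.2 in this assay for now.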

Compound 4, distribution coefficient: 0.31
The estimate for compound 4 lay 0.49 log units above the measured number; the whole stated range lies above it.
By their numbers in this assay, from the lowest: compounds 2, 3 and 4 (each within the scatter of the next, the first and the last beyond it); then compound 1.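

In this assay the change from methoxy to cyclopropyl on a saturated chain carbon bound to a carbonyl carbon reads as a number 0.25 log units higher from compound 3 to compound 4 (within the scatter) and does not separate the two compounds. Against the sulfonyl compounds the readings are a number 0.48 log units higher from compound 2 to compound 4 (beyond the scatter) and a number 0.56 log units lower from compound 1 to compound 4 (beyond the scatter) and so the (cyclopropylmethyl)carbonyl group stands clear of methylsulfonyl, which (methoxymethyl)carbonyl did not do.

As far as these compounds go, whether an amine, a carboxylic acid or a longer chain at this place would move the number beyond the scatter stays open. Nothing measured here accounts for these steps.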